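A few compounds are considered here, and "the series" means these few. Any claim that something is new, unique, unknown or untested is made for them only; others in the source may bear on it.

Measured in an assay on U2OS cells for activation of nuclear factor erythroid 2-related factor 2 (Homo sapiens), read by beta-arrestin recruitment, with a stated time of 6 h; a lower number here means that less compound is needed, a higher number that more compound is needed for the effect:

Compound 1 `O=S(=O)(/C=C/c1ccccn1)c1ccccc1F` gives 1050 nM
Compound 2 `O=S(=O)(/C=C/c1ncccc1F)c1ccc(F)cc1` gives 542 nM
Compound 3 `O=S(=O)(/C=C/c1ncccc1Cl)c1ccc(F)cc1` gives 231 nM

Compound 1 stands highest of the three; its nearest neighbour is compound 2, and the gap between those two is within the usual scatter, so no order is read between them. The gap from compound 1 to compound 3 is beyond the scatter. The difference between the core of compound 1 and the core of compound 2 is not broken down here.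

One change is seen twice in the set. From compound 2 to compound 3 it is chloro in place of fluoro on an aromatic carbon and it gave a 2.3-fold lower number from compound 2 to compound 3 (0.37 log units; beyond the scatter) in this assay. From compound 1 to compound 4 `O=S(=O)(/C=C/c1ccccn1)c1ccccc1Cl`, which is not yet measured, it is chloro in place of fluoro on an aromatic carbon. The two are the same kind of change rather than the same: in compound 3 the chloro sits on a six-membered aromatic ring with 1 nitrogen, two atoms from the ring nitrogen, whereas in compound 4 it sits on a six-membered aromatic ring of carbon only, in both cases ortho to a large group.

Given that, compound 4 is expected to give 450 nM in this assay, between 200 nM and 1000 nM. Among the compounds with values here, that estimate means a step of a 2.3-fold lower number from compound 1 to compound 4 (0.37 log units; beyond the scatter) and rests on the single earlier step, because a 2.3-fold lower number from compound 2 to compound 3 (0.37 log units; beyond the scatter) set that size; the estimate is loose, as the ring around the place differs and only one example is at hand.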

Compound 4, half-maximal effective concentration: 618 nM
Beside the measured number, compound 4's estimate is 1.4-fold (0.14 log units) below it; measured number inside the range.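

In this assay, chloro in place of fluoro on an aromatic carbon gave a 1.7-fold lower number from compound 1 to compound 4 (0.23 log units; within the scatter), so on the core of compound 1 this step taken alone cannot be told apart from repeat scatter. Set beside the earlier step, it gives no sign that the size of the change depends on the core, and as far as these two pairs go, the change carries from one core to the other: the same change on two cores in this assay, a 2.3-fold lower number (0.37 log units; beyond the scatter) from compound 2 to compound 3 and a 1.7-fold lower number (0.23 log units; within the scatter) from compound 1 to compound 4, 1.4-fold (0.14 log units) apart, within the scatter of two such steps

This does not show that chloro in place of fluoro has a real effect on the core of compound 1, nor that a step of this size would hold on any further core, and two pairs, one with the chloro on a six-membered aromatic ring with 1 nitrogen and one with it on a six-membered aromatic ring of carbon only, cannot say why the numbers move as they do.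

The compounds shown leave open how other groups would read in the same place, for example bromo, methyl, methoxy or nitrile. They also leave open whether an amine or a carboxylic acid would be tolerated on either core, and how the difference between the two cores breaks down.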